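Cytotoxicity notes: alkyl and sulfonyl variation on the aromatic nitrogen

The source may hold more compounds than are shown below. What is called first, only, known or untested is meant among the compounds shown, and "the series" means these compounds.

Measured so far in an ADME assay on MT4 cells (Homo sapiens) for cytotoxicity, read by MTT assay, with a stated time of 5 days; on this read-out lower numbers stand for higher toxicity in this test and higher numbers for lower toxicity in this test:
compound 1 `CC(C)N(c1ccnc(Nc2ccc(C#N)cc2)n1)c1c(F)cc(-c2ccc(C#N)cc2)cc1F` gives 172000 nM
compound 2 `CC(C)CN(c1ccnc(Nc2ccc(C#N)cc2)n1)c1c(F)cc(-c2ccc(C#N)cc2)cc1F` gives 241000 nM
compound 3 `CCC(C)N(c1ccnc(Nc2ccc(C#N)cc2)n1)c1c(F)cc(-c2ccc(C#N)cc2)cc1F` gives 217000 nM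

All three share one core and differ only in the group on the nitrogen on the aromatic ring. Compound 2 sits at one end of the three numbers, but the gap to compound 3 a 1.1-fold lower number from compound 2 to compound 3 (0.05 log units; within the scatter) and the gap from compound 1 a 1.4-fold higher number from compound 1 to compound 2 (0.15 log units; within the scatter) are both within the scatter; the step of a 1.3-fold higher number from compound 1 to compound 3 (0.10 log units; within the scatter) is as well. Within these three the branched alkyl groups are indistinguishable in this assay.

Compound 4 `CCS(=O)(=O)N(c1ccnc(Nc2ccc(C#N)cc2)n1)c1c(F)cc(-c2ccc(C#N)cc2)cc1F` is not yet measured. Its change from compound 2 is ethylsulfonyl in place of isobutyl on a nitrogen on an aromatic ring. Among the compounds with values here, none of the measured steps bears directly on this exchange: every step seen so far swaps one alkyl group for another, and none introduces a sulfonyl group or new hydrogen-bond acceptors. The measured steps give no sign of movement in this assay for changes at this nitrogen, so no step beyond the scatter is expected for compound 4 either, in either direction, though the range must be wide for lack of a comparable step.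

The expected step from compound 2 is a 1.2-fold lower number from compound 2 to compound 4 (0.08 log units; within the scatter). Compound 4 is estimated at 200000 nM, between 80000 nM and 450000 nM.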

Compound 4, half-maximal cytotoxic concentration: > 125000 nM
Compound 4 was reported as a limit (the forecaster's own chance of this, stated with the estimate: 25%); the middle value is on the limit's open side.
By their numbers in this assay, from the lowest: compounds 1, 3 and 2 (each within the scatter of the next).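

In this assay, within the data shown here, compound 4 is reported only as a limit, > 125000 nM, and no step to it from compound 1, compound 2 or compound 3 can be read. The compounds shown leave open whether ethylsulfonyl, in place of isopropyl, isobutyl or sec-butyl on a nitrogen on an aromatic ring, moves the number in this assay in either direction.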